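This account rests on a few compounds, and the source may have more. Where it says the series, first, only, none or still open, it means among the compounds named here.

Working notes on the amide series sharing the core of compound 1.

Three compounds in the series carry measured values. Compound 1 `O=C(NCCO)c1cc(-c2ccc(Cl)cc2Cl)n[nH]1` gives 44 nM in an assay on isolated protein for inhibition of alkaline phosphatase, tissue-nonspecific isozyme (Homo sapiens); on this read-out higher numbers stand for weaker inhibition and lower numbers for stronger inhibition. Compound 2 `CC(C)NC(=O)c1cc(-c2ccc(Cl)cc2Cl)n[nH]1` gives 51 nM in this assay, and compound 3 `O=C(NCCCCO)c1cc(-c2ccc(Cl)cc2Cl)n[nH]1` gives 35 nM. The three measured steps, a 1.2-fold higher number from compound 1 to compound 2 (0.06 log units; within the scatter), a 1.3-fold lower number from compound 1 to compound 3 (0.10 log units; within the scatter) and a 1.5-fold lower number from compound 2 to compound 3 (0.16 log units; within the scatter), all lie within the scatter, so the amide substituent has so far moved the read-out hardly at all. Compound 3 gives the lowest of the three numbers, but the gaps to compound 1 and compound 2 are both within the scatter, so no ranking can be read from them.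

Compound 4 `COCCNC(=O)c1cc(-c2ccc(Cl)cc2Cl)n[nH]1` is the next member to be measured in this assay. It differs from compound 3 by methoxy in place of 2-hydroxyethyl on a saturated chain carbon, two bonds along the chain from an amide-type nitrogen. The changes that bear on it are a 1.3-fold lower number from compound 1 to compound 3 (0.10 log units; within the scatter), which lengthens the hydroxy-bearing chain, and a 1.5-fold lower number from compound 2 to compound 3 (0.16 log units; within the scatter), which replaces a branched substituent with a hydroxybutyl chain; neither exceeded the scatter. Since every variation of the amide substituent so far has stayed within the scatter, no step beyond the scatter is expected here either, and the estimated step is a 1.2-fold higher number from compound 3 to compound 4 (0.08 log units; within the scatter). Compound 4 is therefore expected to give about 42 nM in this assay, with a range from 20 nM to 90 nM.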

Compound 4, half-maximal inhibitory concentration: 46 nM
Compound 4: the middle estimate sits 1.1-fold (0.04 log units) below what was measured; measured number inside the range.
By their numbers in this assay, from the lowest: compounds 3, 1, 4 and 2 (each within the scatter of the next).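

In this assay, among the compounds shown here, methyl in place of hydrogen on an oxygen on a saturated carbon gives a 1.0-fold higher number from compound 1 to compound 4 (0.02 log units; within the scatter) and so offers the first comparison in which the chain stays the same and only the hydroxy end is capped; the loss of that hydrogen-bond donor produces no step beyond the scatter. The change from 4-hydroxybutyl to 2-methoxyethyl gives a 1.3-fold higher number from compound 3 to compound 4 (0.12 log units; within the scatter) and 2-methoxyethyl in place of isopropyl gives a 1.1-fold lower number from compound 2 to compound 4 (0.04 log units; within the scatter) as well, so the methoxy-ended chain joins the hydroxy-ended and branched substituents with no separation among them in this read-out. No supporting data bear on why this position tolerates these changes.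

All four amide substituents shown are uncharged open chains, so it remains open whether a primary amine, a carboxylic acid or a ring-bearing substituent on the amide nitrogen would give a step beyond the scatter. Also open, going by these compounds, is whether a much longer ether chain, or a methyl in place of the amide hydrogen, would separate from this group.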